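A 4-fluorophenyl group replaces ethyl

The source may report more compounds than this note shows. Statements on the series, on what has been measured and on what is new or still open speak of the compounds shown alone.

In an ADME assay on Vero 76 cells (Chlorocebus sabaeus) for cytotoxicity, read by crystal violet staining, with a stated time of 96 h (on this read-out lower numbers stand for higher toxicity in this test and higher numbers for lower toxicity in this test), compound 2 `CCNC(=S)Nc1cccc(C(F)(F)F)c1` gives > 100000 nM, which is a limit of the assay and not a number. Compound 3 `Fc1ccc(NC(=S)Nc2cccc(C(F)(F)F)c2)cc1` has not yet been measured. It carries 4-fluorophenyl in place of ethyl on an amide-type nitrogen. Within the data shown here, one measured step bears on this change. Compound 1 `FC(F)(F)c1cccc(NC(=S)Nc2ccc(Cl)cc2)c1` gives 11000 nM and holds 4-chlorophenyl at that same kind of nitrogen. Putting ethyl in place of 4-chlorophenyl gave an at least 9.0-fold higher number from compound 1 to compound 2 (0.95 log units; beyond the scatter), a change beyond the scatter. Compound 3 reverses that kind of swap, so on the strength of that step a move toward a lower number is expected, of similar size. The expected step in this assay is an at least 6.6-fold lower number from compound 2 to compound 3 (0.82 log units; beyond the scatter). For compound 3 the estimated value is 15000 nM, with an expected range from 6000 nM to 40000 nM.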

Compound 3, half-maximal cytotoxic concentration: 40000 nM
Beside the measured number, compound 3's estimate is 2.7-fold (0.43 log units) below it; measured number inside the range.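

In this assay, 4-fluorophenyl in place of ethyl gives an at least 2.5-fold lower number from compound 2 to compound 3 (0.39 log units; beyond the scatter), so the lower number seen with 4-chlorophenyl in compound 1 also appears with a second halogen-bearing phenyl ring on this amide-type nitrogen. The halogen matters as well: fluoro in place of chloro on an aromatic carbon gives a 3.6-fold higher number from compound 1 to compound 3 (0.56 log units; beyond the scatter), so the two aryl compounds do not behave alike in this test. Compound 2 sits at a limit of the assay and not at a number, so the true size of the ethyl-to-aryl step stays unknown: the limit of > 100000 nM in this assay, at which 1 of the 3 values shown sits.

From the compounds shown here alone, it remains open how much of the effect comes from the ring itself and how much from its halogen, which a plain phenyl ring or a longer chain such as butyl on this nitrogen could help separate. Going by these compounds, the role of the thiocarbonyl also remains open, since all three compounds carry it and none has a carbonyl in its place.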